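The source may hold more compounds than are shown below. What is called first, only, known or untested is meant among the compounds shown, and "the series" means these compounds.

Series notes. Compound 1 `C[Se]/C(=N\C(=O)c1cccs1)NC(=O)c1cccs1` and compound 2 `O=C(/N=C(/NC(=O)c1cccs1)[Se]Cc1ccccc1)c1cccs1` share one core; compound 3 `O=C(/N=C(/NC(=O)c1csc([N+](=O)[O-])c1)[Se]Cc1ccccc1)c1csc([N+](=O)[O-])c1` and compound 4 `C[Se]/C(=N\C(=O)c1csc([N+](=O)[O-])c1)NC(=O)c1csc([N+](=O)[O-])c1` share another, and the difference between the two cores is not broken down here. In a functional assay on PC-3 cells (Homo sapiens) for cytotoxicity, read by MTT assay, with a stated time of 72 h (on this read-out higher numbers stand for weaker inhibition of growth and lower numbers for stronger inhibition of growth), compound 1 gives 1340 nM, and compound 2 gives 49900 nM. The change hydrogen in place of phenyl on a saturated chain carbon bound to a selenium atom therefore made a large step, a 37-fold lower number from compound 2 to compound 1 (1.57 log units; beyond the scatter). In this assay compound 3 gives 35900 nM, a value within the scatter of that of compound 2. Compound 4 carries the same change on the second core, (hydrogen in place of phenyl on a saturated chain carbon bound to a selenium atom), at the same place, a saturated chain carbon bound to a selenium atom. A step of similar size is expected, a 24-fold lower number from compound 3 to compound 4 (1.38 log units; beyond the scatter), though held somewhat more cautious. Among the compounds with values here, that expectation rests on a 37-fold lower number from compound 2 to compound 1 (1.57 log units; beyond the scatter) as the only precedent. Compound 4 is estimated at 1500 nM, with a likely range from 400 nM to 6000 nM.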

Compound 4, concentration for 50% growth inhibition: 100 nM
For compound 4 the middle estimate is 15-fold (1.18 log units) above the measured one, and the stated range ends above it.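

In this assay the change from benzyl to methyl again gives a large step on the second core, a 360-fold lower number from compound 3 to compound 4 (2.56 log units; beyond the scatter). The direction carries over between the two cores, but the size does not: the same change on two cores in this assay, a 37-fold lower number (1.57 log units; beyond the scatter) from compound 2 to compound 1 and a 360-fold lower number (2.56 log units; beyond the scatter) from compound 3 to compound 4, 9.6-fold (0.98 log units) apart, beyond the scatter of two such steps The step on one core therefore gave the direction on the other but not its size, and two pairs do not show why the sizes differ or how the change would behave on any further core.

Open, from the compounds shown here alone, is where an ethyl group or a longer chain in place of the methyl or benzyl group would fall on this read-out. Also open, going by these compounds, is whether an amine or a carboxylic acid in place of the nitro group would change the size of the step.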